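The compounds below may be only part of what the source reports. "The series", "measured", "known", "first", "only" and "open" are said of these compounds alone.

Among the compounds with values here, in an ADME assay on Vero cells (Chlorocebus sabaeus) for cytotoxicity, read by crystal violet staining (a higher number here means that more compound is tolerated, a lower number that less compound is tolerated), compound 1 `CN(C)CCCN(/N=N/c1ccc([N+](=O)[O-])cc1)c1ccccc1` gives 40000 nM and compound 2 `CN(C)CCCN(/N=N/c1ccccc1)c1ccccc1` gives 35000 nM and so stands within the scatter of compound 1, the only other measured member of the series (a 1.1-fold lower number from compound 1 to compound 2 (0.06 log units; within the scatter)). Compound 3 `Cc1ccc(/N=N/N(CCCN(C)C)c2ccccc2)cc1` carries methyl in place of hydrogen on an aromatic carbon of compound 2, para to a large group (methyl in place of hydrogen on an aromatic carbon). Within the data shown here, one measured step bears on this change: going from nitro to hydrogen on an aromatic carbon left the number within the scatter (a 1.1-fold lower number from compound 1 to compound 2 (0.06 log units; within the scatter)). That is a single step with a different group, so it is weak support, but it gives no reason to expect a shift from methyl in this assay. The expected step is no larger than the scatter (no change at the digits printed from compound 2 to compound 3 (within the scatter)). The estimate for compound 3 is 35000 nM (expected range 20000 nM to 60000 nM).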

Compound 3, half-maximal cytotoxic concentration: 100000 nM
Estimate against measurement, compound 3: 2.9-fold (0.46 log units) below; measured number above the stated range.
By their numbers in this assay, from the lowest: compounds 2 and 1 (each within the scatter of the next); then compound 3.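

In this assay, the position para to a large group is not silent: methyl in place of hydrogen gives a 2.9-fold higher number from compound 2 to compound 3 (0.46 log units; beyond the scatter) and so moves the number beyond the scatter. Methyl in place of nitro gives a 2.5-fold higher number from compound 1 to compound 3 (0.40 log units; beyond the scatter) and points the same way, so compound 3 stands apart from both compound 1 and compound 2, which lie within the scatter of each other. Nothing measured here accounts for this shift.

As far as these compounds go, whether the higher number belongs to methyl alone, or also appears with ethyl, methoxy or an amine at this position, stays open. From the compounds shown here alone, how methyl behaves elsewhere on the aromatic rings of the shared core is equally open.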